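Trifluoromethoxy to Methyl: Expected Effect on Cell Growth Inhibition

A few compounds are considered here, and "the series" means these few. Any claim that something is new, unique, unknown or untested is made for them only; others in the source may bear on it.

Three compounds sharing one core were tested in a functional assay on MCF7 cells (Homo sapiens) for inhibition, read by sulforhodamine B assay, with a stated time of 72 h; a higher number here means a weaker inhibitor, a lower number a stronger inhibitor. Compound 1 `COc1ccc2cc(C(C)c3nnc4n3N=C(c3ccc([N+](=O)[O-])cc3)CS4)ccc2c1` gives 18800 nM. Compound 3 `COc1ccc2cc(C(C)c3nnc4n3N=C(c3ccc(Cl)cc3)CS4)ccc2c1` gives 10100 nM, and the step of a 1.9-fold lower number from compound 1 to compound 3 (0.27 log units; within the scatter) stays within the scatter. Compound 2 `CC(c1ccc(-c2ccccc2)c(F)c1)c1nnc2n1N=C(c1ccc(OC(F)(F)F)cc1)CS2` gives 4800 nM, the lowest of the three numbers, beyond the scatter from both compound 3 and compound 1. Compound 4 `Cc1ccc(C2=Nn3c(nnc3C(C)c3ccc(-c4ccccc4)c(F)c3)SC2)cc1` differs from compound 2 by methyl in place of trifluoromethoxy on an aromatic carbon. Going by the values given here, the only measured step that alters the group on that same ring, a 1.9-fold lower number from compound 1 to compound 3 (0.27 log units; within the scatter), was small, so this change is expected to move this assay little, most likely within the scatter and with no clear direction. Compound 4 is therefore estimated at 7000 nM, between 2500 nM and 20000 nM, an expected step of a 1.5-fold higher number from compound 2 to compound 4 (0.16 log units; within the scatter).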

Compound 4, half-maximal inhibitory concentration: 5000 nM
The estimate for compound 4 lay 1.4-fold (0.15 log units) above the measured number, within the range that was stated.
By their numbers in this assay, from the lowest: compounds 2 and 4 (each within the scatter of the next); then compounds 3 and 1 (each within the scatter of the next).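

In this assay, replacing trifluoromethoxy with methyl gives a 1.0-fold higher number from compound 2 to compound 4 (0.02 log units; within the scatter). The earlier step at this ring position exchanged nitro for chloro on compounds with a different group elsewhere, whereas this one shows that, alongside the group carried by compound 2, five heavy atoms can give way to one, with one hydrogen-bond acceptor fewer, and the number stays within the scatter. Nothing measured here offers a reason for this result. Still open, from the compounds shown here alone, is whether an amine or a carboxylic acid at this position would also stay within the scatter.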